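Removing a methyl from an inactive pair: compound 3

This account rests on a few compounds, and the source may have more. Where it says the series, first, only, none or still open, it means among the compounds named here.

compound 1 `CN(C)c1nc(Br)nc2c1ncn2[C@@H]1C[C@@H](O)[C@H](CO)O1`: > 300 uM
compound 2 `CSc1nc(N(C)C)c2ncn([C@@H]3C[C@@H](O)[C@H](CO)O3)c2n1`: > 300 uM

In a functional assay on HL-60 cells (Homo sapiens) (on this read-out lower numbers stand for stronger inhibition and higher numbers for weaker inhibition), compound 1 gives only the limit > 300 uM. Compound 2 likewise gives only the limit > 300 uM. The step that the two limits leave unreadable from compound 1 to compound 2 is thus unreadable, both values sitting at the limit of > 300 uM in this assay, at which 2 of the 2 values shown sit. Compound 3 `CNc1nc(Br)nc2c1ncn2[C@@H]1C[C@@H](O)[C@H](CO)O1` differs from compound 1 by hydrogen in place of methyl on a nitrogen on an aromatic ring. Within the data shown here, no measured step bears on this change, and compound 1 itself supplies no number. The step of a number no higher from compound 1 to compound 3 (the limit leaves the size open) is expected to leave compound 3 near the same limit, a readable value being unlikely. Compound 3 is therefore estimated at 300 uM, within 100 uM to 1000 uM.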

Compound 3, concentration for 50% inhibition: 143 uM
Compound 3: the middle estimate sits 2.1-fold (0.32 log units) above what was measured; the measured number falls inside the stated range.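

In this assay, among these compounds, hydrogen in place of methyl on a nitrogen on an aromatic ring gives an at least 2.0-fold lower number from compound 1 to compound 3 (0.32 log units; beyond the scatter), so this position can respond to a change even though the earlier compounds showed none. Going by these compounds, the full size of the step stays open, as compound 1 gives only a limit. Compound 3 is the only compound here to give a number rather than a limit: the limit of > 300 uM in this assay, at which 2 of the 3 values shown sit.

On these data alone, whether a free amino group or an ethyl group on this nitrogen would lower the number further remains open. Also open, as far as these compounds go, is whether methylamino keeps a readable value with methylsulfanyl in place of bromo.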